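The source may hold more compounds than are shown below. What is called first, only, known or untested is meant among the compounds shown, and "the series" means these compounds.

Measured so far in a functional assay on SGC-7901 cells (Homo sapiens) for inhibition, read by MTT assay, with a stated time of 72 h; a lower number here means a stronger inhibitor of growth, a higher number a weaker inhibitor of growth:
compound 1 `O[C@H](COCCOC[C@@H](O)Cc1cn(-c2cccs2)nn1)Cc1ccc(-c2ccccc2)cc1`: 33400 nM
compound 3 `O[C@H](COCCOC[C@@H](O)Cc1cn(Cc2ccc(C(F)(F)F)cc2)nn1)Cc1ccc(-c2ccccc2)cc1`: 8700 nM
Compound 2 `O[C@H](COCCOC[C@@H](O)Cc1c[nH]nn1)Cc1ccc(-c2ccccc2)cc1` gives only a limit of this assay, > 100000 nM.

Compound 3 holds the lowest of the two numbers; the step of a 3.8-fold lower number from compound 1 to compound 3 (0.58 log units; beyond the scatter) separates it from compound 1. Compound 4 `O=c1[nH]c2ccc(-n3cc(C[C@H](O)COCCOC[C@@H](O)Cc4ccc(-c5ccccc5)cc4)nn3)cc2s1` differs from compound 3 by a group of 10 heavy atoms (7 carbon, 1 nitrogen, 1 oxygen, 1 sulfur; one five-membered aromatic ring with 2 hetero atoms, one six-membered aromatic ring of carbon only) in place of a group of 11 heavy atoms (8 carbon, 3 fluorine; one six-membered aromatic ring of carbon only), on an aromatic nitrogen. The measured steps on this aromatic nitrogen are an at least 11-fold lower number from compound 2 to compound 3 (1.06 log units; beyond the scatter) and a 3.8-fold lower number from compound 1 to compound 3 (0.58 log units; beyond the scatter): a larger group in place of hydrogen or thiophen-2-yl lowered the number, while the nature of the large group is tested only once. Compound 4 keeps a large aromatic group there, so a step of a 1.0-fold higher number from compound 3 to compound 4 (0.01 log units; within the scatter) within the scatter is expected. For compound 4 the value is estimated at 9000 nM, in the range 3000 nM to 27000 nM.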

Compound 4, concentration for 50% growth inhibition: 10500 nM
Compound 4: the middle estimate sits 1.2-fold (0.07 log units) below what was measured; the measured number falls inside the stated range.
By their numbers in this assay, from the lowest: compounds 3 and 4 (each within the scatter of the next); then compound 1. At a limit, above all of these: compound 2.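

In this assay, a second large group on the aromatic nitrogen, with no fluorine and with a hydrogen-bond donor, reads level with 4-(trifluoromethyl)benzyl: a 1.2-fold higher number from compound 3 to compound 4 (0.08 log units; within the scatter). That group also gives a lower number than thiophen-2-yl, a 3.2-fold lower number from compound 1 to compound 4 (0.50 log units; beyond the scatter), and than hydrogen, an at least 9.5-fold lower number from compound 2 to compound 4 (0.97 log units; beyond the scatter), so two differently built large groups now stand within the scatter of each other. The step from hydrogen rests on a limit for compound 2: the limit of > 100000 nM in this assay, at which 1 of the 4 values shown sits.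

Going by these compounds, what a plain benzyl, an amine or a carboxylic acid on this aromatic nitrogen would give stays open.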